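The source may hold more compounds than are shown below. What is called first, only, known or untested is meant among the compounds shown, and "the series" means these compounds.

Measured so far in a functional assay on MCF7 cells (Homo sapiens) for inhibition, read by CCK-8 assay, with a stated time of 48 h; a lower number here means a stronger inhibitor of growth, a higher number a weaker inhibitor of growth:
compound 1 `Cc1ccccc1Nc1nc(Nc2ccc(N3CCN(C)CC3)cc2)ncc1Cl` gives 20600 nM
compound 2 `CCN1CCN(c2ccc(Nc3ncc(Cl)c(Nc4ccccc4C)n3)cc2)CC1` gives 3160 nM
compound 3 `CCc1ccc(Nc2nc(Nc3ccc(N4CCN(C)CC4)cn3)ncc2Cl)cc1` gives 8230 nM

Compound 1 and compound 2 differ by methyl in place of hydrogen on a saturated chain carbon bound to an amine nitrogen in a ring. That change gave a 6.5-fold lower number from compound 1 to compound 2 (0.81 log units; beyond the scatter). The difference between the cores of compound 1 and compound 3 is not broken down here; compound 3 stands between the two in this assay.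

Compound 4 `CC(C)c1ccc(Nc2nc(Nc3ccc(N4CCN(C)CC4)cn3)ncc2Cl)cc1` is not yet measured. It differs from compound 3 by methyl in place of hydrogen on a saturated chain carbon bound to an aromatic carbon and a saturated chain carbon. This is the same kind of change as that from compound 1 to compound 2, not the same: there the place was a saturated chain carbon bound to an amine nitrogen in a ring, here it is a saturated chain carbon bound to an aromatic carbon and a saturated chain carbon. A smaller step is expected from compound 3 to compound 4 in this assay, about a 1.5-fold lower number from compound 3 to compound 4 (0.18 log units; within the scatter), because a 6.5-fold lower number from compound 1 to compound 2 (0.81 log units; beyond the scatter) rests on a single pair at a different place. Compound 4 is estimated at 5500 nM, expected between 2000 nM and 15000 nM.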

Compound 4, concentration for 50% growth inhibition: 1880 nM
For compound 4 the middle estimate is 2.9-fold (0.47 log units) above the measured one; measured number below the stated range.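

In this assay, ethyl to isopropyl gave a 4.4-fold lower number from compound 3 to compound 4 (0.64 log units; beyond the scatter). Set beside the earlier methyl step, the two steps do not differ in size: the same change on two cores in this assay, a 6.5-fold lower number (0.81 log units; beyond the scatter) from compound 1 to compound 2 and a 4.4-fold lower number (0.64 log units; beyond the scatter) from compound 3 to compound 4, 1.5-fold (0.17 log units) apart, within the scatter of two such steps. This shows a lower number for the added methyl on both cores, but each core rests on a single pair and the methyl sits at a different place in each, and nothing here shows that the step holds on other cores in this series.

Left open is how a tert-butyl, a cyclopropyl or a longer chain in place of the isopropyl would read in this assay. Also open, from the compounds shown here alone, is whether a hydroxyl or an amine at that place would keep the lower number.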